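Methoxy to ethoxy on compound 3: expected step

A few compounds are considered here, and "the series" means these few. Any claim that something is new, unique, unknown or untested is made for them only; others in the source may bear on it.

- compound 1 `COc1ccccc1-c1ncc(C(=O)O)c(=O)[nH]1` gives 10 mg/kg
- compound 2 `CCOc1ccccc1-c1ncc(C(=O)O)c(=O)[nH]1` gives 0.5 mg/kg
- compound 3 `COc1ccc(OC)c(-c2ncc(C(=O)O)c(=O)[nH]2)c1` gives 1 mg/kg

All three values come from a functional assay on the whole organism (strain Sprague-Dawley) for inhibition, with Rattus norvegicus as the target, with a stated time of 10 min; on this read-out lower numbers stand for an effect already at smaller amounts and higher numbers for an effect only at larger amounts of compound. Compound 3 lies within the scatter of compound 2 and well apart from compound 1, the measured step being a 10-fold lower number from compound 1 to compound 3 (1.00 log units; beyond the scatter). That step is methoxy in place of hydrogen on an aromatic carbon.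

Compound 4 `CCOc1ccc(OC)cc1-c1ncc(C(=O)O)c(=O)[nH]1` follows from compound 3 by methyl in place of hydrogen on a saturated chain carbon bound to an oxygen on an aromatic ring, which reads as methoxy to ethoxy. The same change has been measured once, as a 20-fold lower number from compound 1 to compound 2 (1.30 log units; beyond the scatter). Among the measured compounds shown here, that single precedent lacks the added methoxy of compound 3, and no measured compound yet carries both changes, so the full size of the precedent may not carry over. A step in the same direction but smaller is therefore expected. The estimated step is a 5.0-fold lower number from compound 3 to compound 4 (0.70 log units; beyond the scatter). Compound 4 is expected at 0.2 mg/kg, with an estimated range of 0.04 mg/kg to 1 mg/kg.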

Compound 4, dose for 50% inhibition: 0.2 mg/kg
Beside the measured number, compound 4's estimate shows no gap at the digits printed; the range from low to high includes it.
By their numbers in this assay, from the lowest: compound 4; then compounds 2 and 3 (each within the scatter of the next); then compound 1.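

Methoxy to ethoxy still lowers the number when the added methoxy is present, with a 5.0-fold lower number from compound 3 to compound 4 (0.70 log units; beyond the scatter), but this step is smaller than on the core of compound 1: the same change on two cores in this assay, a 20-fold lower number (1.30 log units; beyond the scatter) from compound 1 to compound 2 and a 5.0-fold lower number (0.70 log units; beyond the scatter) from compound 3 to compound 4, 4.0-fold (0.60 log units) apart, beyond the scatter of two such steps.

The added methoxy likewise still lowers the number when ethoxy is present, with a 2.5-fold lower number from compound 2 to compound 4 (0.40 log units; beyond the scatter), and again the step is smaller: the same change on two cores in this assay, a 10-fold lower number (1.00 log units; beyond the scatter) from compound 1 to compound 3 and a 2.5-fold lower number (0.40 log units; beyond the scatter) from compound 2 to compound 4, 4.0-fold (0.60 log units) apart, beyond the scatter of two such steps.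

These two comparisons rest on the same four compounds and describe a single observation: each change is worth less in the presence of the other, so the two do not add in full.

From the compounds shown here alone, whether a longer chain such as propoxy or a branched one such as isopropoxy lowers the number further remains open. So does whether chlorine or an amine in place of the added methoxy would give a similar step.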